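A Methoxy Moves From the Side Chain to the Core

The source may report more compounds than this note shows. Statements on the series, on what has been measured and on what is new or still open speak of the compounds shown alone.

Measured so far:
compound 1, `COc1ccc(COCNc2n[n+]([O-])c3ccccc3[n+]2[O-])cc1`, 7640 nM
compound 2, `[O-][n+]1nc(NCOCc2ccccc2)[n+]([O-])c2ccccc21`, 10800 nM
compound 3, `CCCCCOCNc1n[n+]([O-])c2ccccc2[n+]1[O-]`, 6460 nM

Of the compounds shown here, three have been measured in a functional assay on A549 cells (Homo sapiens) for cytotoxicity, read by MTT assay, with a stated time of 72 h; a higher number here means a weaker inhibitor, a lower number a stronger inhibitor. All three share one core and differ only in the group on the chain attached to it. Compound 2 and compound 1 differ by methoxy in place of hydrogen on an aromatic carbon; the step was a 1.4-fold lower number from compound 2 to compound 1 (0.15 log units; within the scatter). Compound 2 and compound 3 differ by butyl in place of phenyl on a saturated chain carbon bound to an oxygen on a saturated carbon; the step was a 1.7-fold lower number from compound 2 to compound 3 (0.22 log units; within the scatter). Between compound 1 and compound 3 the step was a 1.2-fold lower number from compound 1 to compound 3 (0.07 log units; within the scatter). Thus none of the three is set apart from the others by more than the usual scatter, and compound 3 sits at the lowest number among them only nominally.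

Compound 4, `CCCCCOCNc1n[n+]([O-])c2cc(OC)ccc2[n+]1[O-]`, has not yet been measured in this assay. It differs from compound 3 by methoxy in place of hydrogen on an aromatic carbon. This is the same kind of change as that from compound 2 to compound 1, but not the same one: there the methoxy entered on a six-membered aromatic ring of carbon only, para to a large group; here it enters on a ring that is part of a fused or bridged system of two rings, meta to a fused ring and para to a fused ring, that is, on the shared core rather than on the chain. Since the earlier step of a 1.4-fold lower number from compound 2 to compound 1 (0.15 log units; within the scatter) stayed within the scatter, the expected step from compound 3 to compound 4 is likewise small, a 1.2-fold lower number from compound 3 to compound 4 (0.07 log units; within the scatter), and rests on that single precedent only. For compound 4 the number estimated in this assay is 5500 nM, expected to fall between 2500 nM and 12000 nM.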

Compound 4, half-maximal inhibitory concentration: 5040 nM
Beside the measured number, compound 4's estimate is 1.1-fold (0.04 log units) above it; the range from low to high includes it.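

In this assay the methoxy placed on the shared core gave only a small step (a 1.3-fold lower number from compound 3 to compound 4 (0.11 log units; within the scatter)), so on this evidence the change is as quiet on the core as it was on the benzene ring of the side chain. Set side by side, the two occurrences of the change do not differ: the same change on two cores in this assay, a 1.4-fold lower number (0.15 log units; within the scatter) from compound 2 to compound 1 and a 1.3-fold lower number (0.11 log units; within the scatter) from compound 3 to compound 4, 1.1-fold (0.04 log units) apart, within the scatter of two such steps. This shows that, for these two pairs, swapping hydrogen for methoxy left the number within the scatter wherever it was carried, but it does not show that methoxy improves cytotoxicity in this series, since neither step can be told from repeat measurement, and two small steps from a single assay on one cell line cannot establish a general rule of transfer.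

Still open, from the compounds shown here alone, is whether an amine or a carboxylic acid in place of the methoxy on the core, or a longer chain in place of the butyl, would produce a step beyond the scatter. The compounds shown also leave open how the methoxy on the core behaves when the chain carries phenyl or 4-methoxyphenyl rather than butyl.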